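This account rests on a few compounds, and the source may have more. Where it says the series, first, only, none or still open, it means among the compounds named here.

In an ADME assay on Huh-7 cells (Homo sapiens) for cytotoxicity, with a stated time of 24 h (on this read-out higher numbers stand for lower toxicity in this test and lower numbers for higher toxicity in this test), the series reads:
- compound 1 `COc1ccc(/C=C\c2cc(OC)c(OC)c(OC)c2)cc1NC(=O)[C@H](CO)NC(=O)[C@H](CCCNC(=N)N)NC(=O)[C@H](CCCCN)NC(=O)c1ccccc1` gives 77900 nM as a number
- compound 2 `COc1ccc(/C=C\c2cc(OC)c(OC)c(OC)c2)cc1NC(=O)[C@H](C)NC(=O)[C@H](CCCNC(=N)N)NC(=O)[C@H](CCCCN)NC(=O)c1ccccc1` gives > 100000 nM as a limit of the assay
- compound 3 `COc1ccc(/C=C\c2cc(OC)c(OC)c(OC)c2)cc1NC(=O)CNC(=O)[C@H](CCCNC(=N)N)NC(=O)[C@H](CCCNC(=N)N)NC(=O)c1ccccc1` gives 88600 nM as a number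

Compound 3 at 88600 nM and compound 1 at 77900 nM lie within the scatter of each other. Compound 2 gives no number, only its limit.

The change leading to compound 4 `COc1ccc(/C=C\c2cc(OC)c(OC)c(OC)c2)cc1NC(=O)CNC(=O)[C@H](CCCNC(=N)N)NC(=O)[C@H](CCCCN)NC(=O)c1ccccc1` is a group of 2 heavy atoms (1 carbon, 1 nitrogen; no ring) in place of a group of 4 heavy atoms (1 carbon, 3 nitrogen; no ring), on a saturated chain carbon, four bonds along the chain from an amide-type nitrogen and a carbonyl carbon with aminomethyl as the group that enters. Within the data shown here, no measured step covers this exchange. Among the measured compounds shown here, the one measured step bears on it only loosely: an at least 1.2-fold higher number from compound 1 to compound 2 (0.10 log units; that floor lies within the scatter) is a different change, hydrogen in place of hydroxy, and its floor lies within the scatter. It gives no reason to expect a large move here, and no direction.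

No change beyond the scatter is therefore expected: the estimated 1.0-fold higher number from compound 3 to compound 4 (0.01 log units; within the scatter) stays within it. Compound 2 shows the limit of > 100000 nM in this assay, at which 1 of the 3 values shown sits, and the same limit could also be what compound 4 returns. The estimated value in this assay for compound 4 is 90000 nM with an expected range from 55000 nM to 140000 nM for a numeric result.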

Compound 4, half-maximal cytotoxic concentration: > 100000 nM
Compound 4: a limit, no number (the forecaster's own chance of this, stated with the estimate: 35%); middle value at least 1.1-fold (0.04 log units) away from the limit.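

In this assay compound 4 gives > 100000 nM, a limit and not a number, so the exchange of the group of 4 heavy atoms for aminomethyl, on a saturated chain carbon, four bonds along the chain from an amide-type nitrogen and a carbonyl carbon, can be read only as a floor: an at least 1.1-fold higher number from compound 3 to compound 4 (0.05 log units; that floor lies within the scatter). At the other changed place, hydrogen in place of hydroxymethyl reads an at least 1.2-fold higher number from compound 1 to compound 4 (0.10 log units; that floor lies within the scatter), while the step between compound 2 and compound 4 cannot be read, as both values are limits. The new result adds a second compound at the ceiling of the read-out, so neither change shows any sign of higher toxicity in this test, and the series now gives less numeric resolution than the earlier compounds suggested: the limit of > 100000 nM in this assay, at which 2 of the 4 values shown sit.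

Going by these compounds, how far compound 4 and compound 2 lie past that limit remains unknown, so their order and the true size of the floors stay unresolved. On these data alone, it also remains open whether a carboxylic acid or a longer amine chain on that saturated chain carbon would return a number rather than a limit.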